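Taking one ester group off compound 3

A few compounds are considered here, and "the series" means these few. Any claim that something is new, unique, unknown or untested is made for them only; others in the source may bear on it.

Three compounds on a shared core have numbers in a functional assay on MDA-MB-231 cells (Homo sapiens) for antiproliferative activity, read by MTT assay, with a stated time of 72 h; a lower number here means a stronger inhibitor, a higher number a weaker inhibitor. Compound 2 (`CC(CO)(CO)C(=O)Oc1ccc(/C=C/C(=O)/C=C(O)/C=C/c2ccc(OC(=O)C(C)(CO)CO)cc2)cc1`) gives 6740 nM and compound 3 (`COc1ccc(/C=C/C(=O)/C=C(O)/C=C/c2ccc(OC)c(OC(=O)C(C)(CO)CO)c2)cc1OC(=O)C(C)(CO)CO`) gives 4610 nM, and compound 1 (`CCC(CO)(CO)C(=O)Oc1ccc(/C=C/C(=O)/C=C(O)/C=C/c2ccc(O)c(OC)c2)cc1OC`) gives 4660 nM. Compound 3 holds the lowest of these numbers, but all three lie within the usual scatter, so it stands level with the others. Compound 4 (`COc1ccc(/C=C/C(O)=C/C(=O)/C=C/c2ccc(OC)c(OC(=O)C(C)(CO)CO)c2)cc1O`) has hydrogen in place of (1,1-bis(hydroxymethyl)ethyl)carbonyl on an oxygen on an aromatic ring. Within the data shown here, no measured pair shows this change alone. Compound 1 also carries a hydroxy on an aromatic ring and gives 4660 nM, so no step beyond the scatter is expected. The estimated step is a 1.0-fold lower number from compound 3 to compound 4 (0.01 log units; within the scatter). For compound 4 the expected value is 4500 nM, with an estimated range from 2200 nM to 9500 nM.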

Compound 4, half-maximal inhibitory concentration: 2290 nM
Compound 4: the middle estimate sits 2.0-fold (0.29 log units) above what was measured; measured number inside the range.
By their numbers in this assay, from the lowest: compounds 4, 3, 1 and 2 (each within the scatter of the next, the first and the last beyond it).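

Replacing one (1,1-bis(hydroxymethyl)ethyl)carbonyl with hydrogen, which leaves a hydroxy on the aromatic ring, gives a 2.0-fold lower number from compound 3 to compound 4 (0.30 log units; within the scatter) in this assay. Among these compounds, this is the first measured pair that differs in one place, and it shows that on this oxygen the ester can give way to hydroxy with no change beyond the scatter. No measured evidence here bears on this result. On these data alone, it remains open whether an acetyl group on this oxygen would read level with these compounds. As far as these compounds go, it also remains open whether the second ester could be replaced by hydrogen.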